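Removing the long chain from a chloro compound

The source may hold more compounds than are shown below. What is called first, only, known or untested is meant among the compounds shown, and "the series" means these compounds.

In an ADME assay on J774 cells (Mus musculus) for cytotoxicity (a higher number here means that more compound is needed for the effect, a lower number that less compound is needed), compound 1 (`CCCCC#Cc1c(C)[nH]c2ccccc2c1=O`) gives 8900 nM as a true measured number. Compound 2 (`CCCCC#Cc1c(C)[nH]c2ccc(Cl)cc2c1=O`) stands at > 36300 nM and this is a limit of the assay, not a number. Compound 3 (`CCCCCCCCCc1c(C)[nH]c2cc(OC)c(Cl)cc2c1=O`) stands at > 28700 nM and this too is a limit, not a number. For the measured compounds named here, compound 3 therefore has no exact place on the scale, and compound 2 is the only other compound in that situation.

Compound 4 (`COc1cc2[nH]c(C)c(C)c(=O)c2cc1Cl`) differs from compound 3 by hydrogen in place of octyl on a saturated chain carbon bound to an aromatic carbon. Going by the values given here, no measured step involves a change of this kind, so the guidance is only indirect. Among the compounds with values here, the single measured step swaps chloro for hydrogen on an aromatic carbon and gives an at least 4.0-fold higher number from compound 1 to compound 2 (0.61 log units; beyond the scatter) as its size. Compound 4 keeps the chloro group, so it is expected to stay on the side where more compound is needed. The estimated change is a step that the limit leaves unreadable from compound 3 to compound 4 in this assay and no step beyond the scatter is expected. For compound 4 the expected value is 40000 nM with an estimated range of 12000 nM to 100000 nM and the assay may well report only a limit.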

Compound 4, half-maximal effective concentration: 12200 nM
The estimate for compound 4 lay 3.3-fold (0.52 log units) above the measured number; low and high end bracket the measured number.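

For the compounds shown here, this result gives the first measured change at this place on the chain: with hydrogen in place of octyl on a saturated chain carbon bound to an aromatic carbon, this assay shows an at least 2.3-fold lower number from compound 3 to compound 4 (0.37 log units; beyond the scatter). Less compound is therefore needed for the effect once the octyl has gone, and this change is larger than the usual scatter of the assay. Only the lowest possible size of the step can be read, and the true size stays unknown because compound 3 stands at a limit of the assay and not at a number: the limit of > 28700 nM in this assay, at which 1 of the 4 values shown sits.

The compounds shown leave open whether the number falls gradually as the chain gets shorter or whether a chain of intermediate length, such as butyl, would already behave like hydrogen, and whether an amine or a carboxylic acid at the end of the chain would change the outcome. They also leave open whether the same swap of octyl for hydrogen would give a step of similar size on a core without the chloro and methoxy groups.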